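This account rests on a few compounds, and the source may have more. Where it says the series, first, only, none or still open, it means among the compounds named here.

In a functional assay on MCF7 cells (Homo sapiens) for antiproliferative activity, read by MTT assay, with a stated time of 72 h (a higher number here means a weaker inhibitor, a lower number a stronger inhibitor), compound 1 `CCN(CC)CCCOc1cc2ncnc(Nc3ccc(C#N)cc3)c2cc1OC` sits at > 100000 nM as a limit of the assay. Compound 2 `COc1cc2c(Nc3ccc(C#N)cc3)ncnc2cc1OCCCN1CCC(CO)CC1` gives 35100 nM as a measured number. Compound 3 `COc1cc2c(Nc3ccc(C#N)cc3)ncnc2cc1OCCCN1CCN(C)CC1` gives 71100 nM and stands higher of the two measured numbers. Compound 4 `CCN1CCN(CCCOc2cc3ncnc(Nc4ccc(C#N)cc4)c3cc2OC)CC1` differs from compound 3 by methyl in place of hydrogen on a saturated chain carbon bound to an amine nitrogen in a ring in the terminal group, with methyl in place of hydrogen on a saturated chain carbon bound to an amine nitrogen in a ring, which turns 4-methylpiperazin-1-yl to 4-ethylpiperazin-1-yl. Within the data shown here, no measured step adds a single methyl alone. The closest are exchanges of the whole amine: a 2.0-fold higher number from compound 2 to compound 3 (0.31 log units; beyond the scatter) is modest and an at least 1.4-fold lower number from compound 1 to compound 3 (0.14 log units; that floor lies within the scatter) has its floor within the scatter. Both exchange more than this change does, so no step beyond the scatter is expected in this assay. The expected step is a 1.2-fold lower number from compound 3 to compound 4 (0.07 log units; within the scatter) and remains an estimate. Compound 4 is expected at 60000 nM with an estimated range from 25000 nM to 120000 nM for now.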

Compound 4, half-maximal inhibitory concentration: 29900 nM
Compound 4: middle estimate off by 2.0-fold (0.30 log units), on the high side; low and high end bracket the measured number.
By their numbers in this assay, from the lowest: compounds 4 and 2 (each within the scatter of the next); then compound 3. At a limit, above all of these: compound 1.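

In this assay the methyl on a saturated chain carbon bound to an amine nitrogen in a ring gives a 2.4-fold lower number from compound 3 to compound 4 (0.38 log units; beyond the scatter) as the only single-methyl step shown, so even this small change reads beyond the scatter here. Exchanges of the whole amine give a 1.2-fold lower number from compound 2 to compound 4 (0.07 log units; within the scatter) and so leave the 4-ethylpiperazin-1-yl and 4-(hydroxymethyl)piperidin-1-yl compounds unseparated, and an at least 3.3-fold lower number from compound 1 to compound 4 (0.52 log units; beyond the scatter) as a floor only. Compound 1 stands at a limit: the limit of > 100000 nM in this assay, at which 1 of the 4 values shown sits.

As far as these compounds go, whether 4-propylpiperazin-1-yl or 4-(2-hydroxyethyl)piperazin-1-yl would carry the methyl step further stays open.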